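The source may report more compounds than this note shows. Statements on the series, on what has been measured and on what is new or still open speak of the compounds shown alone.

Measured compounds:
compound 1, `Nc1nc(N)nc(-c2cc(F)ccc2Cl)n1`, 1.38
compound 2, `Nc1nc(N)nc(-c2cc(Br)ccc2Cl)n1`, 2.04
compound 3, `Nc1nc(N)nc(-c2cc(F)ccc2Br)n1`, 1.45

All three share one core and differ only in the halogens on the carbon ring. The read-out is a physicochemical assay for lipophilicity; on this read-out lower numbers stand for lower lipophilicity and higher numbers for higher lipophilicity. Going from compound 1 to compound 2 the change is bromo in place of fluoro on an aromatic carbon and the step is a number 0.66 log units higher from compound 1 to compound 2 (beyond the scatter). Going from compound 1 to compound 3 the change is bromo in place of chloro on an aromatic carbon and the step is a number 0.07 log units higher from compound 1 to compound 3 (within the scatter), so these two values cannot be told apart.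

Compound 4, `Nc1nc(N)nc(-c2cc(Br)ccc2Br)n1`, has not been measured in this assay . It differs from compound 3 by bromo in place of fluoro on an aromatic carbon. Among the measured compounds shown here, this is the same kind of change as the one from compound 1 to compound 2, though not the same: there the changed carbon is para to a chloro group, here it is para to a bromo group. Since the earlier change gave a number 0.66 log units higher from compound 1 to compound 2 (beyond the scatter), a step of about a number 0.66 log units higher from compound 3 to compound 4 (beyond the scatter) is expected from compound 3 to compound 4. Compound 4 is therefore estimated at 2.11, between 1.8 and 2.42.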

Compound 4, partition coefficient: 2.09
Compound 4: the middle estimate sits 0.02 log units above what was measured; the range from low to high includes it.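

In this assay, putting bromo in place of fluoro gives a number 0.64 log units higher from compound 3 to compound 4 (beyond the scatter), and this is close in size to a number 0.66 log units higher from compound 1 to compound 2 (beyond the scatter), so in these two cases the change carries over whether the changed carbon is para to a chloro group or para to a bromo group. Putting bromo in place of chloro gives a number 0.05 log units higher from compound 2 to compound 4 (within the scatter), so those two values cannot be told apart. Among the compounds shown here, this is only two matched pairs on one shared core, and it does not show that the step would hold on a different core or at another place on the ring.

No measurement shown here explains the size of these steps. Also open, going by these compounds, is how this read-out would respond if an amine, a carboxylic acid or a longer chain stood on the carbon ring in place of one of these halogens.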